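Thiosemicarbazone series on MCF7: methoxy on the aryl ring

The source may report more compounds than this note shows. Statements on the series, on what has been measured and on what is new or still open speak of the compounds shown alone.

The isothiocyanate compound 1 `CC1=CC[C@H](C(C)(C)N=C=S)CC1` opens the series. In a functional assay on MCF7 cells (Homo sapiens) for inhibition, read by sulforhodamine B assay, with a stated time of 48 h (a lower number here means a stronger inhibitor of growth, a higher number a weaker inhibitor of growth), compound 1 returns only > 100000 nM, which is a limit of the assay and not a number. Among the measured compounds shown here, the benzylidene thiosemicarbazide compound 2 `CC1=CC[C@H](C(C)(C)NC(=S)N/N=C/c2ccccc2)CC1` is the sole member with a measured figure: in this assay compound 2 gives 84400 nM. That is the only number shown for the series, the one further value being the limit described by the limit of > 100000 nM in this assay, at which 1 of the 2 values shown sits.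

Compound 3 `COc1ccc(/C=N/NC(=S)NC(C)(C)[C@H]2CC=C(C)CC2)cc1` differs from compound 2 in a single place: methoxy in place of hydrogen on an aromatic carbon. For the measured compounds named here, no step between two measured compounds exists that would calibrate a change of this kind, so there is no basis for expecting a shift beyond the scatter in either direction. Compound 3 is therefore expected to sit close to compound 2, with the step of a 1.1-fold lower number from compound 2 to compound 3 (0.05 log units; within the scatter) taken as nil within scatter. The estimate for compound 3 in this assay is 75000 nM, expected to fall between 25000 nM and 200000 nM. A fair chance remains that only a limit is returned for compound 3.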

Compound 3, concentration for total growth inhibition: 37700 nM
For compound 3 the middle estimate is 2.0-fold (0.30 log units) above the measured one; the measured number falls inside the stated range.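

Phenyl to 4-methoxyphenyl gives a 2.2-fold lower number from compound 2 to compound 3 (0.35 log units; beyond the scatter) in this assay, the first step in the series that can be read between two measured numbers. It shows that the aromatic carbon para to a large group is not a silent position: methoxy in place of hydrogen there yields a lower number, modest in size but beyond the scatter. This is one group at one position, so it sets no trend for the ring, and the step alone does not tie the change to any property of methoxy.

Still open, on these data alone, is whether the same step would appear with a hydroxyl, a chlorine, a dimethylamino group or a carboxylic acid on that carbon, and whether methoxy on another carbon of the ring would match it. Compound 1 stays outside any comparison, as its value is a limit of the assay and not a number: the limit of > 100000 nM in this assay, at which 1 of the 3 values shown sits.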